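Hydroxamate series: varying the substituent on the ring nitrogen

The source may report more compounds than this note shows. Statements on the series, on what has been measured and on what is new or still open speak of the compounds shown alone.

Measured compounds:
compound 1 `Cc1ccc(-c2cnc(N(Cc3ccc(C(=O)NO)cc3)CC(C)C)s2)cc1` 5900 nM
compound 2 `Cc1ccc(OCCCN(Cc2ccc(C(=O)NO)cc2)c2ncc(-c3ccc(C)cc3)s2)cc1` 12600 nM
compound 3 `Cc1ccc(-c2cnc(N(CCCCOc3ccccc3)Cc3ccc(C(=O)NO)cc3)s2)cc1` 680 nM

In a functional assay on HCT-116 cells (Homo sapiens) for antiproliferative activity, read by MTT assay, with a stated time of 48 h (a lower number here means a stronger inhibitor of growth, a higher number a weaker inhibitor of growth), compound 3 gives the lowest number of the three, separated from compound 1 by an 8.7-fold lower number from compound 1 to compound 3 (0.94 log units; beyond the scatter) and from compound 2 by a 19-fold lower number from compound 2 to compound 3 (1.27 log units; beyond the scatter); both gaps lie beyond the scatter. Compound 4 `Cc1ccc(-c2cnc(N(Cc3ccc(C(=O)NO)cc3)C(C)C)s2)cc1` has not yet been run in this assay. It differs from compound 3 in one place: isopropyl in place of 4-phenoxybutyl on a nitrogen on an aromatic ring. The shortened nitrogen substituent makes compound 4 close in build to compound 1, whose structure is shown above.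

Within the data shown here, the step that bears most directly is the one from compound 1 to compound 3, an 8.7-fold lower number from compound 1 to compound 3 (0.94 log units; beyond the scatter), where a phenoxyalkyl chain arrived in place of isopropyl; the step from compound 1 to compound 2, a 2.1-fold higher number from compound 1 to compound 2 (0.33 log units; beyond the scatter), shows that a longer substituent is not always favourable. Among the measured compounds shown here, removing the 4-phenoxybutyl chain is therefore expected to raise the number, by roughly the size of the first of these steps in reverse, a 7.4-fold higher number from compound 3 to compound 4 (0.87 log units; beyond the scatter). Compound 4 is expected to give about 5000 nM in this assay, with a likely range from 1500 nM to 16000 nM.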

Compound 4, concentration for 50% growth inhibition: 7800 nM
Compound 4: the middle estimate sits 1.6-fold (0.19 log units) below what was measured; low and high end bracket the measured number.
By their numbers in this assay, from the lowest: compound 3; then compounds 1, 4 and 2 (each within the scatter of the next, the first and the last beyond it).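

In this assay, an 11-fold higher number from compound 3 to compound 4 (1.06 log units; beyond the scatter), a large step that sets the 4-phenoxybutyl chain directly against a small branched group on this nitrogen. Isopropyl and isobutyl on the same nitrogen cannot be told apart, a 1.3-fold higher number from compound 1 to compound 4 (0.12 log units; within the scatter), so a change of this size among small alkyl groups leaves the number within the scatter. Isopropyl also cannot be told apart from 3-(4-methylphenoxy)propyl, a 1.6-fold lower number from compound 2 to compound 4 (0.21 log units; within the scatter), so compound 2 goes against any reading that a long aryl ether chain on this nitrogen lowers the number, and among the four compounds only compound 3 stands apart.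

Still open, as far as these compounds go, is whether the ether oxygen is needed, which a 4-phenylbutyl chain would test, and how a 5-phenoxypentyl chain or a chain ending in an amine would compare with 4-phenoxybutyl. Nothing shown accounts for the gap between compound 3 and the others.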